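Aryl methyl-to-fluoro exchange in a cytotoxicity series

The compounds below may be only part of what the source reports. "The series", "measured", "known", "first", "only" and "open" are said of these compounds alone.

Measured compounds:
Compound 1 `Cc1cccc(-c2nc3cc(C)ccc3c(=O)[nH]2)c1` — > 50000 nM
Compound 2 `Cc1ccc2nc(-c3ccccc3C)[nH]c(=O)c2c1` — > 50000 nM
Compound 3 `Cc1ccc2nc(-c3ccccc3F)[nH]c(=O)c2c1` — > 50000 nM

In a functional assay on T47D cells (Homo sapiens) for cytotoxicity, read by MTT assay, with a stated time of 2 days (on this read-out lower numbers stand for stronger inhibition and higher numbers for weaker inhibition), compound 1 gives only a limit, > 50000 nM. Compound 2 likewise gives only a limit in this assay, > 50000 nM. Compound 3 too gives only a limit, > 50000 nM. Within the data shown here, all three values sit at the limit of > 50000 nM in this assay, at which 3 of the 3 values shown sit, so no compound can be ranked against another.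

Compound 1 and compound 2 have the same atoms joined differently; the difference between the two cores is not broken down here. From compound 2 to compound 3 the change is fluoro in place of methyl on an aromatic carbon. The step that the two limits leave unreadable from compound 2 to compound 3 is left unreadable by the two limits.

Compound 4 `Cc1ccc2c(=O)[nH]c(-c3cccc(F)c3)nc2c1` is not yet measured in this assay. It differs from compound 1 by fluoro in place of methyl on an aromatic carbon. This is the same kind of change as that from compound 2 to compound 3, not the same: there the fluoro stands ortho to a large group, here meta to a large group.

Compound 4 is expected to give about 70000 nM, between 20000 nM and 250000 nM. The step that this estimate means is expected to be a step that the limit leaves unreadable from compound 1 to compound 4, one the limits would again hide. The expectation rests on compound 1 giving > 50000 nM. It rests also on compound 3 giving > 50000 nM after the same kind of change. Most likely compound 4 again returns only a limit.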

Compound 4, half-maximal inhibitory concentration: > 50000 nM
Compound 4 ended at the assay's limit; the forecaster's own chance of this, stated with the estimate: 85%; the middle value is on the limit's open side.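

In this assay compound 4 gives > 50000 nM, which is a limit and not a number. No new step can be read between compound 1 and compound 4, because both stand at a limit: the limit of > 50000 nM in this assay, at which 4 of the 4 values shown sit.

The compounds shown leave open how strongly any of the four acts in this assay, and whether fluoro in place of methyl on an aromatic carbon changes the read-out at all.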